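The source may hold more compounds than are shown below. What is called first, only, known or untested is meant among the compounds shown, and "the series" means these compounds.

Measured so far in an assay on a protein complex for binding affinity to Neuronal acetylcholine receptor; alpha4/beta2 (Homo sapiens); on this read-out lower numbers stand for stronger inhibition and higher numbers for weaker inhibition:
compound 1, `O=C(Nc1ccc(Cl)c(Cl)c1)N[C@@H]1C2CCN(CC2)[C@@H]1Cc1cccnc1`, gives a limit, > 10000 nM.
compound 2, `CN(C)c1ccc(NC(=O)N[C@@H]2C3CCN(CC3)[C@@H]2Cc2cccnc2)cc1`, gives a limit, > 10000 nM.

Both values sit at the limit of > 10000 nM in this assay, at which 2 of the 2 values shown sit, so the step that the two limits leave unreadable from compound 1 to compound 2 is not readable. Compound 1 therefore stands only at a limit, with no number for it in this assay.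

Compound 3 is `C/C(=C\C(=O)N[C@@H]1C2CCN(CC2)[C@@H]1Cc1cccnc1)c1ccccc1`. It differs from compound 1 by 2-phenylprop-1-en-1-yl in place of (3,4-dichlorophenyl)amino on a carbonyl carbon. Among the measured compounds shown here, no measured step bears on this change, and the two limits give no direction to expect.

For compound 3 the estimate in this assay is 10000 nM, within 1500 nM to 60000 nM. This means an expected step of a number no higher from compound 1 to compound 3 (the limit leaves the size open), most likely again a limit rather than a number.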

Compound 3, inhibition constant: > 10000 nM
Compound 3 ended at the assay's limit; the forecaster's own chance of this, stated with the estimate: 65%; the middle value sits exactly at the limit.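

Among the compounds shown here, no step from compound 1 to compound 3 can be read, as both values are only limits: the limit of > 10000 nM in this assay, at which 3 of the 3 values shown sit. Going by these compounds, whether any change on the shared core gives a readable number in this assay stays open.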